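Ring-nitrogen substituent change on the bromoacrylamide series

The compounds below may be only part of what the source reports. "The series", "measured", "known", "first", "only" and "open" are said of these compounds alone.

Measured compounds:
compound 1 `C=C(Br)C(=O)Nc1ccc(/C=C2\SC(=O)N(CC)C2=O)cc1` — 870 nM
compound 2 `CC(C)(C)c1ccc(CN2C(=O)S/C(=C\c3ccc(N)cc3)C2=O)cc1` — 66000 nM
compound 3 `CC(C)(C)c1ccc(CN2C(=O)S/C(=C\c3cccc(N)c3)C2=O)cc1` — 165000 nM

In a functional assay on CCRF-CEM cells (Homo sapiens) for cytotoxicity, read by cell counting, with a stated time of 3 days (a higher number here means a weaker inhibitor, a lower number a stronger inhibitor), compound 1 gives the lowest of the three numbers; compound 2 stands nearest to it and compound 3 furthest, both far beyond the scatter. Among the measured compounds shown here, the only step measured is a 2.5-fold higher number from compound 2 to compound 3 (0.40 log units; beyond the scatter), which concerns the aminophenyl group on the double-bonded chain carbon and not the substituent on the ring nitrogen.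

Compound 4 `C=C(Br)C(=O)Nc1ccc(/C=C2\SC(=O)N(Cc3ccc(F)cc3)C2=O)cc1` differs from compound 1 only at that nitrogen: 4-fluorophenyl in place of methyl on a saturated chain carbon bound to an amide-type nitrogen in a ring. For the measured compounds named here, no measured pair isolates this change. Compounds 2 and 3 do carry a benzyl-type group on the ring nitrogen, but they also lack the bromoacrylamide of compound 1, so their values cannot be read as a test of the nitrogen substituent alone.

Going by the values given here, with no step bearing on the change, the expectation for compound 4 is a number close to that of compound 1, with no shift beyond the scatter, giving an estimated step of a 1.2-fold lower number from compound 1 to compound 4 (0.09 log units; within the scatter). Compound 4 is therefore estimated at 700 nM, with a range of 250 nM to 2500 nM.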

Compound 4, half-maximal inhibitory concentration: 2400 nM
Compound 4: middle estimate off by 3.4-fold (0.54 log units), on the low side; the range from low to high includes it.
By their numbers in this assay, from the lowest: compound 1; then compound 4; then compound 2; then compound 3.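

In this assay the substituent on the ring nitrogen gets its first direct reading: with the bromoacrylamide and the rest of the core of compound 1 held fixed, the change from ethyl to 4-fluorobenzyl gives a 2.8-fold higher number from compound 1 to compound 4 (0.44 log units; beyond the scatter) as a modest loss beyond the scatter. The position therefore responds to this change, but it also accepts a six-membered aromatic ring without a collapse of the read-out, as compound 4 still gives 2400 nM in this assay and stays on the same side of the series as compound 1, though this rests on a single pair. Nothing measured here gives a reason for the step.

Among the compounds shown here, with only this pair at the position, the contributions of the aromatic ring and of its fluorine cannot be separated, and an unsubstituted benzyl group or a plain propyl chain would be needed to tell them apart. Going by these compounds, how the position responds to an amine or a carboxylic acid at the end of the chain on the ring nitrogen also remains open.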